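Diaryl ether esters: dimethylamino in place of cyano

The source may hold more compounds than are shown below. What is called first, only, known or untested is meant among the compounds shown, and "the series" means these compounds.

Measured in a functional assay on HL-60 cells (Homo sapiens) for antiproliferative activity; a lower number here means a stronger inhibitor, a higher number a weaker inhibitor:
- compound 1 `COC(=O)c1cccc(Oc2ccc(N(C)C)cc2)c1`: > 20000 nM
- compound 2 `COC(=O)c1cccc(Oc2ccc(OC)cc2)c1`: > 20000 nM
- compound 3 `CCOC(=O)c1ccc(Oc2ccc(C#N)cc2)cc1`: > 20000 nM

Compound 3 stands at > 20000 nM, which is a limit and not a number. Among the compounds with values here, the same holds across the series, with the limit of > 20000 nM in this assay, at which 3 of the 3 values shown sit, so no compound can be ranked against another.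

The move to compound 4 `CCOC(=O)c1ccc(Oc2ccc(N(C)C)cc2)cc1` places dimethylamino in place of cyano on an aromatic carbon, para to a large group: dimethylamino in place of cyano on an aromatic carbon.

Within the data shown here, the one measured step touching this group is a step that the two limits leave unreadable from compound 1 to compound 2, so it gives no size to carry over. Compound 1 already carries dimethylamino and sits at > 20000 nM, again a limit. On that basis, no gain beyond the scatter is expected in this assay, although a number under the limit cannot be ruled out.

The estimated step is a number no higher from compound 3 to compound 4 (the limit leaves the size open).

For compound 4 the expected value is 20000 nM, with an estimated range of 6000 nM to 30000 nM.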

Compound 4, half-maximal inhibitory concentration: > 20000 nM
Compound 4 ended at the assay's limit; the forecaster's own chance of this, stated with the estimate: 70%; the middle value sits exactly at the limit.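

In this assay compound 4 gives > 20000 nM, which is a limit and not a number. Within the data shown here, no step from compound 3 to compound 4 can be read, as both stand at a limit: the limit of > 20000 nM in this assay, at which 4 of the 4 values shown sit. The compounds shown leave open which change to the shared core, if any, would give a measurable number in this assay.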